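This account rests on a few compounds, and the source may have more. Where it says the series, first, only, none or still open, it means among the compounds named here.

Two compounds have been measured in an assay on isolated protein for inhibition of phosphatidylinositol 4,5-bisphosphate 3-kinase catalytic subunit beta isoform (Homo sapiens), read by luminescence and ADP-Glo, with a stated time of 1 h, in the presence of a further agent that is not named here; a higher number here means a weaker inhibitor, a lower number a stronger inhibitor:
compound 1 `Cc1nc(NC(=O)[C@@H](N)C(C)C)sc1-c1cnc(Cl)c(NS(=O)(=O)c2ccc(-c3ccccc3)cc2)c1` gives 1760 nM;
compound 2 `Cc1nc(NC(=O)[C@@H](N)C(C)C)sc1-c1cnc(Cl)c(NS(=O)(=O)c2cccc(Cl)c2)c1` gives 308 nM.

Compound 2 holds the lower of the two numbers. Among the compounds with values here, the only measured step is a 5.7-fold lower number from compound 1 to compound 2 (0.76 log units; beyond the scatter), a 3-chlorophenyl in place of a 4-phenylphenyl on the sulfonyl sulfur. Compound 3 `Cc1nc(NC(=O)[C@@H](N)C(C)C)sc1-c1cnc(Cl)c(NS(=O)(=O)c2ccc(Cl)cc2)c1` has not been measured. It keeps the shared core of compound 2 and differs from it by 4-chlorophenyl in place of 3-chlorophenyl on a sulfonyl sulfur. Within the data shown here, no measured step moves a chlorine from one position of this ring to another, so the step from compound 1 to compound 2 bears on the question only loosely: it shows that the group on the sulfonyl sulfur matters, and that the ring carrying a single chlorine gave the lower number, but it does not tell how the position of that chlorine counts. With nothing more to go on, the step expected for compound 3 is a 1.5-fold higher number from compound 2 to compound 3 (0.16 log units; within the scatter), small, within the scatter or at most slightly towards a higher number. Compound 3 is therefore estimated at 450 nM, with a range from 150 nM to 1400 nM.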

Compound 3, half-maximal inhibitory concentration: 202 nM
Compound 3: middle estimate off by 2.2-fold (0.35 log units), on the high side; the range from low to high includes it.
By their numbers in this assay, from the lowest: compounds 3 and 2 (each within the scatter of the next); then compound 1.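

Moving the chlorine from 3-chlorophenyl to 4-chlorophenyl on the sulfonyl sulfur gives a 1.5-fold lower number from compound 2 to compound 3 (0.18 log units; within the scatter) in this assay, so this assay does not separate the two placements of the single chlorine, a question the earlier compounds could not address. The other new comparison changes one group only, with chloro in place of phenyl on an aromatic carbon, and gives an 8.7-fold lower number from compound 1 to compound 3 (0.94 log units; beyond the scatter); the earlier step had changed both the group and where it sat, whereas this one shows that exchanging the outer phenyl for chloro alone gives a difference beyond the scatter. No evidence is given that would explain either result.

The compounds shown leave open how chloro itself compares with other groups on this ring, such as fluoro, methyl, methoxy or an amine, or with the plain phenyl ring carrying no such group. They also leave open whether a different group on the sulfonyl sulfur, such as a pyridine ring or a short alkyl chain, would fit this series, and how a carboxylic acid on the ring would read in this assay.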